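The source may report more compounds than this note shows. Statements on the series, on what has been measured and on what is new or still open speak of the compounds shown alone.

Series notes, sphingosine 1-phosphate receptor 2 antagonism. In a functional assay on CHO cells for antagonist activity at sphingosine 1-phosphate receptor 2 (Homo sapiens), read by GTPgammaS binding (a higher number here means a weaker inhibitor, a lower number a stronger inhibitor), compound 1 `CCOc1cc2[nH]c(Cc3nn(CC(=O)O)c(=O)c4ccccc34)nc2cc1Cl` gives 109 nM. Compound 2 `COc1cc(OC)c(NC(=O)Cc2cn(CC(=O)O)c3ccccc23)cc1Cl` gives 17700 nM in this assay, the higher of the two numbers and beyond the scatter from compound 1. Compound 3 `COc1cc(OC)c(NC(=O)Cc2cn(C)c3ccccc23)cc1Cl` has not been measured; it differs from compound 2 by hydrogen in place of carboxy on a saturated chain carbon bound to an aromatic nitrogen. Among the measured compounds shown here, no measured pair in this set carries the same change, so the direction is open; a modest weakening, possibly within the scatter, is the working guess. For compound 3 the expected step is a 1.7-fold higher number from compound 2 to compound 3 (0.23 log units; within the scatter). Compound 3 is therefore estimated at 30000 nM, with a range of 10000 nM to 100000 nM.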

Compound 3, half-maximal inhibitory concentration in the sphingosine 1-phosphate receptor 2 assay: 19200 nM
The estimate for compound 3 lay 1.6-fold (0.19 log units) above the measured number; low and high end bracket the measured number.
By their numbers in the sphingosine 1-phosphate receptor 2 assay, from the lowest: compound 1; then compounds 2 and 3 (each within the scatter of the next).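

In the sphingosine 1-phosphate receptor 2 assay, hydrogen in place of carboxy on this saturated chain carbon bound to an aromatic nitrogen gives no readable change: a 1.1-fold higher number from compound 2 to compound 3 (0.04 log units; within the scatter). The carboxy group is therefore not needed for the inhibition seen in this pair, weak as it is. In a physicochemical assay for lipophilicity, at pH 7.4 (a higher number here means a more lipophilic compound, a lower number a more polar compound), compound 2 gives 2.13 and compound 3 gives 5.91. The same change does separate the pair sharply in the physicochemical assay, so lipophilicity at this place moves without any readable shift in inhibition: the measured distribution coefficient of compound 2, 2.13, and of compound 3, 5.91, a number 3.78 log units higher (beyond the scatter)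

As far as these compounds go, what an amine or a longer chain would do at this place stays open. So does whether the same change would leave the number in place on the core of compound 1.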